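This account rests on a few compounds, and the source may have more. Where it says the series, first, only, none or still open, it means among the compounds named here.

In a functional assay on PC-3 cells (Homo sapiens) for inhibition, read by sulforhodamine B assay, with a stated time of 48 h, tested at 10 uM (a lower number here means a stronger effect, a higher number a weaker effect of the compound at the concentration tested), the two measured compounds stand as follows:
compound 1 `COc1cc2cc(Oc3ccc(NC(=O)Nc4ccccc4)cc3)c(C)nc2cc1OC` gives 60.4%;
compound 2 `COc1cc2cc(Oc3ccc(NC(=O)Nc4ccc(C)cc4)cc3)c(C)nc2cc1OC` gives 94.5%.

Compound 2 thus holds the highest of the two numbers, with compound 1 lying beyond the scatter below it. Going by the values given here, the only measured step is a number 34.1 percentage points higher from compound 1 to compound 2 (beyond the scatter), a large change at the same aromatic carbon. Compound 3 `COc1cc2cc(Oc3ccc(NC(=O)Nc4ccc(C(F)(F)F)cc4)cc3)c(C)nc2cc1OC` differs from compound 2 by trifluoromethyl in place of methyl on an aromatic carbon. Among the compounds with values here, no measured step shows a methyl exchanged for a trifluoromethyl, so that single step bears only loosely on it. Compound 3 is therefore expected to stay near compound 2, with a step of a number 6.5 percentage points lower from compound 2 to compound 3 (within the scatter) within the scatter, and an estimate of 88% ranging from 62% to 105%.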

Compound 3, a percentage reported as activity, at one concentration (the size of the read-out at that concentration, not a potency): 48.3%
Estimate against measurement, compound 3: 39.7 percentage points above; the whole stated range lies above it.
By their numbers in this assay, from the lowest: compound 3; then compound 1; then compound 2.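

In this assay, the group on this aromatic carbon, para to a large group, can move the read-out in either direction from hydrogen, which a single methyl step could not show. Trifluoromethyl gives a number 46.2 percentage points lower from compound 2 to compound 3 (beyond the scatter) and, against hydrogen, a number 12.1 percentage points lower from compound 1 to compound 3 (beyond the scatter), making compound 3 the strongest of the three at the concentration tested. No measured evidence accounts for this reversal.

Going by these compounds, whether a chlorine atom, a methoxy group or an amine on this carbon would behave like trifluoromethyl or like methyl remains open. All three numbers show only a stronger or weaker effect at the one concentration tested.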